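Aryl replacement on the shared core: compound 1 to compound 4

This account rests on a few compounds, and the source may have more. Where it says the series, first, only, none or still open, it means among the compounds named here.

Measured so far in an ADME assay on HepG2 cells (Homo sapiens) for cytotoxicity, read by luminescence, CellTiter-Glo and ATP content, with a stated time of 72 h; a lower number here means that less compound is needed, a higher number that more compound is needed for the effect:
compound 1 `COc1cccc(CNCCCNc2ccnc3cc(-c4ccc(C(C)(C)C)cc4)ccc23)c1O` gives 690 nM
compound 2 `Fc1ccc(Cc2ccc3c(NCCCNCc4ccco4)ccnc3c2)cc1` gives 5600 nM
compound 3 `CC(C)(C)c1ccc(-c2ccc3c(NCCCNCc4ccco4)ccnc3c2)cc1` gives 3150 nM

Compound 1 has the lowest number of the three; from compound 1 to compound 3 the step is a 4.6-fold higher number from compound 1 to compound 3 (0.66 log units; beyond the scatter), and compound 2 lies further off still. Compound 4 `COc1cccc(CNCCCNc2ccnc3cc(Oc4cccc(N(C)C)c4)ccc23)c1O` keeps the core and chain of compound 1 and differs in one place: 3-(dimethylamino)phenoxy in place of 4-(tert-butyl)phenyl on an aromatic carbon. Going by the values given here, the one measured step at this same position, a 1.8-fold lower number from compound 2 to compound 3 (0.25 log units; within the scatter), stayed within the scatter, so a change of the aryl group there has so far moved this assay little. The step from compound 1 to compound 4 is therefore expected to be small, a 1.3-fold higher number from compound 1 to compound 4 (0.12 log units; within the scatter), with no firm direction. Compound 4 is estimated at 900 nM, between 350 nM and 2500 nM.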

Compound 4, half-maximal effective concentration: 7300 nM
Compound 4: the middle estimate sits 8.1-fold (0.91 log units) below what was measured; the measured number lies above the stated range.
By their numbers in this assay, from the lowest: compound 1; then compounds 3, 2 and 4 (each within the scatter of the next, the first and the last beyond it).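

In this assay, going by these compounds alone, this position proves far less tolerant than the earlier compounds suggested: the change gives an 11-fold higher number from compound 1 to compound 4 (1.02 log units; beyond the scatter) against a 1.8-fold lower number from compound 2 to compound 3 (0.25 log units; within the scatter) for the only earlier step here. Both groups in the new step have the same heavy-atom count, so a matching count does not keep the number in place; 3-(dimethylamino)phenoxy has 2 hydrogen-bond acceptors and 4-(tert-butyl)phenyl has 0. No measurement here accounts for the step.

Still open, on these data alone, is whether the phenoxy oxygen or the dimethylamino group tracks with the rise; an unsubstituted phenoxy and a 3-(dimethylamino)phenyl would separate the two. Also open, as far as these compounds go, is whether 3-(dimethylamino)phenoxy behaves alike with the furan-2-yl side chain of compound 3.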